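The source may hold more compounds than are shown below. What is called first, only, known or untested is meant among the compounds shown, and "the series" means these compounds.

Measured so far in a functional assay on EA.hy 926 cells (Homo sapiens) for cytotoxicity, read by MTT assay, with stated times of 24 h and 12 h; a lower number here means that less compound is needed, a higher number that more compound is needed for the effect:
- compound 1, `COc1ccc(/C=C/C(=O)O)c(OC(=O)c2nc(C)c(C)nc2C)c1`, gives 115000 nM
- compound 2, `CCOC(=O)/C=C/c1ccc(OC)cc1OC(=O)c1nc(C)c(C)nc1C`, gives 138000 nM
- compound 3, `COc1cc(/C=C/C(=O)O)cc(OC)c1OC(=O)c1nc(C)c(C)nc1C`, gives 34700 nM

Compound 4, `CCOC(=O)/C=C/c1cc(OC)c(OC(=O)c2nc(C)c(C)nc2C)c(OC)c1`, has not been measured. It carries the core of compound 3; how that core differs from the core of compound 1 is not broken down here. Among the measured compounds, compound 3 gives the lowest number in this assay, and its steps to compound 1 and to compound 2 both lie beyond the usual scatter.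

The change from compound 3 to compound 4 is ethyl in place of hydrogen on an oxygen next to a carbonyl group. The same change, (ethyl in place of hydrogen on an oxygen next to a carbonyl group), was made on the core of compound 1, where it gave a 1.2-fold higher number from compound 1 to compound 2 (0.08 log units; within the scatter). Among the compounds with values here, the place of the change reads the same in both pairs, so this is one and the same change made twice in the set, with only one measured instance to go on.

On that single instance, compound 4 is expected to move little from compound 3, a 1.2-fold higher number from compound 3 to compound 4 (0.08 log units; within the scatter), resting on a 1.2-fold higher number from compound 1 to compound 2 (0.08 log units; within the scatter). Compound 4 is accordingly estimated at 42000 nM, with a likely range from 20000 nM to 90000 nM.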

Compound 4, half-maximal effective concentration: 21400 nM
Estimate against measurement, compound 4: 2.0-fold (0.29 log units) above; the range from low to high includes it.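

In this assay, ethyl in place of hydrogen on an oxygen next to a carbonyl group gives a 1.6-fold lower number from compound 3 to compound 4 (0.21 log units; within the scatter), so carboxy to ethoxycarbonyl leaves the number on the core of compound 3 within the scatter. Set beside the earlier instance, the two steps do not differ beyond what repeated measurements allow: the same change on two cores in this assay, a 1.2-fold higher number (0.08 log units; within the scatter) from compound 1 to compound 2 and a 1.6-fold lower number (0.21 log units; within the scatter) from compound 3 to compound 4, 1.9-fold (0.29 log units) apart, within the scatter of two such steps. The change therefore carries over between these two cores as a step too small to read, but this rests on two pairs only and shows neither a direction for the change nor that it would stay this small on a further core.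

Open, on these data alone, is how a longer chain on that oxygen, or an amide in place of the ester, would behave in this assay. Also open, as far as these compounds go, is whether the change would keep this size on a core carrying chlorine in place of a methoxy group.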